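Ortho substitution on the anilide and cytotoxicity

The source may hold more compounds than are shown below. What is called first, only, known or untested is meant among the compounds shown, and "the series" means these compounds.

Within the series sharing the core of compound 1 `O=C(CSc1snnc1-c1ccc(Br)cc1Br)Nc1cccnc1Cl`, compound 3 `O=C(CSc1snnc1-c1ccc(Br)cc1Br)Nc1ccccc1` is the only member with a number rather than a limit. In an ADME assay on MT4 cells (Homo sapiens) for cytotoxicity, read by MTT assay, with a stated time of 5 days (a lower number here means that less compound is tolerated, a higher number that more compound is tolerated), compound 3 gives 24800 nM. For compound 1 the value is a limit, > 240000 nM. For compound 2 `O=C(CSc1snnc1-c1ccc(Br)cc1Br)Nc1ccccc1Cl` the value is likewise a limit, > 240000 nM. The relevant evidence is the limit of > 240000 nM in this assay, at which 2 of the 3 values shown sit. The steps into compound 3 read an at least 9.6-fold lower number from compound 1 to compound 3 (0.98 log units; beyond the scatter) and an at least 9.6-fold lower number from compound 2 to compound 3 (0.98 log units; beyond the scatter), while the step that the two limits leave unreadable from compound 1 to compound 2 cannot be read from two limits.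

Compound 4 `Cc1ccccc1NC(=O)CSc1snnc1-c1ccc(Br)cc1Br` differs from compound 3 by methyl in place of hydrogen on an aromatic carbon. The step of an at least 9.6-fold lower number from compound 2 to compound 3 (0.98 log units; beyond the scatter) bears on it most directly: removing a chloro from that aromatic carbon lowered the number, so placing a methyl there is expected to move the number back up, possibly as far as the limit again. Compound 4 is therefore expected at 110000 nM, with a range from 25000 nM to 240000 nM. That estimate implies a step of a 4.4-fold higher number from compound 3 to compound 4 (0.65 log units; beyond the scatter) in this assay, expected to lie beyond the scatter.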

Compound 4, half-maximal cytotoxic concentration: 202000 nM
Compound 4: the middle estimate sits 1.8-fold (0.26 log units) below what was measured; the range from low to high includes it.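

In this assay, methyl on an aromatic carbon ortho to a large group gives an 8.1-fold higher number from compound 3 to compound 4 (0.91 log units; beyond the scatter), so the move away from the unsubstituted phenyl is no longer tied to chloro alone. The steps against the two limits read an at least 1.1-fold lower number from compound 2 to compound 4 (0.07 log units; that floor lies within the scatter) and an at least 1.1-fold lower number from compound 1 to compound 4 (0.07 log units; that floor lies within the scatter); neither separates methyl from chloro, or 2-methylphenyl from 2-chloropyridin-3-yl. The upper end of the series therefore stays poorly resolved: the limit of > 240000 nM in this assay, at which 2 of the 4 values shown sit.

The compounds shown leave open whether a methoxy, an amine or a carboxylic acid on this carbon would also give a higher number than compound 3. They also leave open whether a longer chain such as ethyl would hold the number reached by methyl in compound 4.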